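Exchanging the benzyl for a trimethylphenyl on the amine

The compounds below may be only part of what the source reports. "The series", "measured", "known", "first", "only" and "open" are said of these compounds alone.

Compound 3 `CN1CCN(c2ccc(Nc3ncc(Cl)c(NCc4ccc(C(F)(F)F)cc4)n3)nc2)CC1` is assessed in a functional assay on MDA-MB-231 cells (Homo sapiens) for inhibition, read by CCK-8 assay, with a stated time of 48 h (a higher number here means a weaker inhibitor of growth, a lower number a stronger inhibitor of growth), where compound 3 gives 19100 nM. Of the two numbers reported, this is the highest; the nearest is compound 2 `CCN1CCN(c2ccc(Nc3ncc(Cl)c(Nc4ccccc4C)n3)cc2)CC1`, which gives 3040 nM. Compound 1 `Cc1ccc(Nc2ncc(Cl)c(Nc3ccccc3C)n2)cc1` sits at the limit of > 100000 nM in this assay, at which 1 of the 3 values shown sits; its value, > 100000 nM, is a limit of the assay and not a number. Going by the values given here, the single measured step is an at least 32-fold lower number from compound 1 to compound 2 (1.51 log units; beyond the scatter); it concerns the piperazine end of the shared core, not the nitrogen altered here.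

Compound 4 `Cc1cc(C)c(Nc2nc(Nc3ccc(N4CCN(C)CC4)cn3)ncc2Cl)c(C)c1` differs from compound 3 by 2,4,6-trimethylphenyl in place of 4-(trifluoromethyl)benzyl on a nitrogen on an aromatic ring. Among the compounds with values here, no measured step touches this nitrogen, so the step from compound 1 to compound 2 gives no direct size for the present change. What the numbers do show is that compound 2, which carries a ring of carbon only on that nitrogen together with a piperazine, sits well below compound 3. The writer therefore expects a lower number for compound 4 than for compound 3, with wide uncertainty, as a 3.8-fold lower number from compound 3 to compound 4 (0.58 log units; beyond the scatter). Compound 4 is estimated at 5000 nM, within a range from 1200 nM to 25000 nM.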

Compound 4, concentration for 50% growth inhibition: 21000 nM
Beside the measured number, compound 4's estimate is 4.2-fold (0.62 log units) below it, and the stated range covers the measured number.
By their numbers in this assay, from the lowest: compound 2; then compounds 3 and 4 (each within the scatter of the next). At a limit, above all of these: compound 1.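

Going by these compounds alone, measured in this assay this pair supplies the first step at this nitrogen, and it reads as a 1.1-fold higher number from compound 3 to compound 4 (0.04 log units; within the scatter) on the exchange of 4-(trifluoromethyl)benzyl for 2,4,6-trimethylphenyl. For this pair, then, the two groups are interchangeable in the growth read-out, although the leaving group holds its six-membered aromatic ring of carbon only on the nitrogen through a carbon link and the entering group holds its ring on the nitrogen directly. The information given here contains nothing that bears on why the two groups read alike.

What the compounds shown leave open is whether this indifference extends past the one pair, for instance to a ring on this nitrogen that carries an amine or a carboxylic acid, or to a longer chain in place of the benzyl. As far as these compounds go, compound 2 differs from compound 4 in more than one place, so it remains open how much of the number of compound 2 belongs to the group on this nitrogen and how much to the rest of the molecule.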